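Chain shortening on two cores: working notes toward compound 4

A few compounds are considered here, and "the series" means these few. Any claim that something is new, unique, unknown or untested is made for them only; others in the source may bear on it.

Three compounds of the series carry a number in a functional assay on NCI-H460 cells (Homo sapiens) for cytotoxicity, read by MTT assay, with a stated time of 72 h; a lower number here means a stronger inhibitor, a higher number a weaker inhibitor. Compound 1 `CN(C)CCCNc1nc(-c2ccc(NC(=O)Nc3ccccc3F)cc2)nc2ccsc12` gives 530 nM. Compound 3 `CN(C)CCNc1nc(-c2ccc(NC(=O)Nc3ccccc3F)cc2)nc2ccsc12` differs from compound 1 by dimethylamino in place of (dimethylamino)methyl on a saturated chain carbon, two bonds along the chain from a nitrogen on an aromatic ring; in this assay compound 3 gives 410 nM; the step reads a 1.3-fold lower number from compound 1 to compound 3 (0.11 log units; within the scatter). Compound 2 `CN(C)CCCNc1nc(-c2ccc(NC(=O)Nc3ccc(F)cc3)cc2)nc2c(Cl)c(Cl)sc12` gives 650 nM. The difference between the core of compound 2 and the core of compound 1 is not broken down here. All three numbers sit within the scatter of one another, so no order among them is drawn.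

Compound 4 `CN(C)CCNc1nc(-c2ccc(NC(=O)Nc3ccc(F)cc3)cc2)nc2c(Cl)c(Cl)sc12` has no number yet in this assay. It stands to compound 2 as compound 3 stands to compound 1: the change is dimethylamino in place of (dimethylamino)methyl on a saturated chain carbon, two bonds along the chain from a nitrogen on an aromatic ring. The place description is the same word for word in both pairs, so this is counted as the same change, made twice among the compounds shown. It has one measured precedent, and that precedent lies within the scatter.

For compound 4 the expected step is a 1.3-fold lower number from compound 2 to compound 4 (0.11 log units; within the scatter), worded as an expectation only. That expectation rests on compound 1 and compound 3, whose single instance of the change gave a 1.3-fold lower number from compound 1 to compound 3 (0.11 log units; within the scatter), and on nothing else, since the two cores are not compared by a counted difference. Compound 4 is accordingly estimated at 500 nM, with the likely range running from 250 nM to 1000 nM.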

Compound 4, half-maximal inhibitory concentration: 590 nM
For compound 4 the middle estimate is 1.2-fold (0.07 log units) below the measured one, within the range that was stated.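

In this assay the change from 3-(dimethylamino)propyl to 2-(dimethylamino)ethyl on the core of compound 2 reads a 1.1-fold lower number from compound 2 to compound 4 (0.04 log units; within the scatter) and so stays inside what repeated measurements would give. Set beside the same change on the core of compound 1, the two steps do not differ: the same change on two cores in this assay, a 1.3-fold lower number (0.11 log units; within the scatter) from compound 1 to compound 3 and a 1.1-fold lower number (0.04 log units; within the scatter) from compound 2 to compound 4, 1.2-fold (0.07 log units) apart, within the scatter of two such steps. This shows that the change carries from one core to the other with the same outcome, a step within the scatter on both; it does not show that the shorter chain has any effect of its own, and two pairs, which also differ from each other outside the chain in ways not broken down here, make no rule for other cores in the series.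

The compounds shown leave open how a longer chain than 3-(dimethylamino)propyl, or a chain ending in a morpholine, a piperidine or a primary amine in place of dimethylamino, would read in this assay on either core. They also leave open whether a carboxylic acid at the end of the chain, or a core with bromine in place of chlorine, would give a step beyond the scatter.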